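The source may report more compounds than this note shows. Statements on the series, on what has been measured and on what is new or still open speak of the compounds shown alone.

Compound 1 `CN(C)CCCNc1nc(-c2ccc(NC(=O)Nc3ccccc3F)cc2)nc2ccsc12` gives 730 nM in a functional assay on MKN-45 cells (Homo sapiens) for cytotoxicity, read by MTT assay, with a stated time of 72 h; a higher number here means a weaker inhibitor, a lower number a stronger inhibitor. Compound 2 `CN(C)CCCNc1nc(-c2ccc(NC(=O)Nc3ccccc3Cl)cc2)nc2ccsc12` gives 690 nM in this assay. The difference between the two, (chloro in place of fluoro on an aromatic carbon), produced a 1.1-fold lower number from compound 1 to compound 2 (0.02 log units; within the scatter). Compound 3 `CCN(CC)CCCNc1nc(-c2ccc(NC(=O)Nc3ccc(F)cc3)cc2)nc2c(Cl)c(Cl)sc12` gives 1700 nM in this assay, the highest number of the three measured; the difference between the core of compound 3 and the core of compound 1 is not broken down here. Compound 4 `CCN(CC)CCCNc1nc(-c2ccc(NC(=O)Nc3ccc(Cl)cc3)cc2)nc2c(Cl)c(Cl)sc12` has not yet been measured in this assay. It differs from compound 3 by chloro in place of fluoro on an aromatic carbon. For the measured compounds named here, this is the same kind of change as the one from compound 1 to compound 2, not the same one: there the halogen sits ortho to a large group, here para to a large group. Because a 1.1-fold lower number from compound 1 to compound 2 (0.02 log units; within the scatter) stayed within the scatter, compound 4 is expected to sit close to compound 3, and the step of a 1.1-fold lower number from compound 3 to compound 4 (0.05 log units; within the scatter) is the expected size in this assay. The estimate for compound 4 in this assay is 1500 nM, expected to fall between 700 nM and 3400 nM. Going by the values given here, nothing among the measured compounds suggests the different core of compound 3 would change the size of this step.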

Compound 4, half-maximal inhibitory concentration: 720 nM
Beside the measured number, compound 4's estimate is 2.1-fold (0.32 log units) above it; the range from low to high includes it.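

Chloro in place of fluoro on an aromatic carbon produces a 2.4-fold lower number from compound 3 to compound 4 (0.37 log units; beyond the scatter) in this assay, a modest step. Set side by side, the steps on the two cores cannot be told apart, and the change shows no measurable dependence on the core: the same change on two cores in this assay, a 1.1-fold lower number (0.02 log units; within the scatter) from compound 1 to compound 2 and a 2.4-fold lower number (0.37 log units; beyond the scatter) from compound 3 to compound 4, 2.2-fold (0.35 log units) apart, within the scatter of two such steps. For the compounds shown here, this does not establish that the step is equal on both cores: only two pairs are at hand, and the halogen is para to a large group only in compound 3 and compound 4, leaving any effect of the core unseparated from any effect of the halogen's place.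

Still open, going by these compounds, is whether the step holds for bromo, methyl or trifluoromethyl at the para place, and for a halogen at the same place on the core of compound 1. Also open, on these data alone, is how a longer chain or a morpholine in place of the terminal amine would alter these steps.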